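Benzyl substituent change on a shared diaminoaryl core

The compounds below may be only part of what the source reports. "The series", "measured", "known", "first", "only" and "open" are said of these compounds alone.

Compound 1 `Nc1cc(N)c2nc(-c3ccccc3)c(Oc3ccc(Cl)c(Cl)c3)nc2c1`: in a functional assay on SK-MEL-28 cells (Homo sapiens) for inhibition, read by sulforhodamine B assay, with a stated time of 48 h (on this read-out higher numbers stand for lower toxicity in this test and lower numbers for higher toxicity in this test), compound 1 gives a limit, < 100000 nM.
Compound 2 `CCOC(=O)[C@H](CCC(=O)O)NC(=O)c1ccc(CNc2nc3cc(N)cc(N)c3nc2-c2ccccc2)cc1`: in this assay compound 2 likewise gives a limit, < 100000 nM.
Compound 3 `Nc1cc(N)c2nc(-c3ccccc3)c(NCc3ccc(Cl)c(Cl)c3)nc2c1`: in this assay compound 3 gives 93300 nM.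

Among the compounds with values here, compound 3 is the only member with a number in this assay; the other two sit at the limit of < 100000 nM in this assay, at which 2 of the 3 values shown sit, so compound 3 cannot be ranked against them, and its own value lies close to that limit.

Compound 4 `COc1ccc(CNc2nc3cc(N)cc(N)c3nc2-c2ccccc2)cc1OC` is the next entry, not yet measured. It differs from compound 3 by 3,4-dimethoxyphenyl in place of 3,4-dichlorophenyl on a saturated chain carbon bound to a nitrogen on an aromatic ring. Within the data shown here, no pair of measured compounds shows this or any other single change, so the series itself gives no measured step to lean on. With all three measured members either at the limit or near it, the working expectation for compound 4 is a step from compound 3 of no more than the scatter, in either direction, written as a 1.2-fold lower number from compound 3 to compound 4 (0.07 log units; within the scatter). On that basis compound 4 is estimated at 80000 nM in this assay, with a range from 25000 nM to 150000 nM, and a fair chance that the assay again returns only a limit.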

Compound 4, concentration lethal to 50% of the cells: 67600 nM
Beside the measured number, compound 4's estimate is 1.2-fold (0.07 log units) above it; the range from low to high includes it.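

In this assay, 3,4-dimethoxyphenyl in place of 3,4-dichlorophenyl on a saturated chain carbon bound to a nitrogen on an aromatic ring gives a 1.4-fold lower number from compound 3 to compound 4 (0.14 log units; within the scatter). Within the data shown here, this is the first single change that can be read, and at this place the two groups cannot be told apart, although the entering group has 2 hydrogen-bond acceptors and the leaving group has 0. Steps to compounds 1 and 2 cannot be read, because their values are limits and not numbers: the limit of < 100000 nM in this assay, at which 2 of the 4 values shown sit.

Still open, from the compounds shown here alone, is whether a phenyl ring carrying a nitrile or a trifluoromethyl at this place, or a longer chain, would give a step beyond the scatter. Also open, going by these compounds, is whether this change would read the same way on any other cell line.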